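This account rests on a few compounds, and the source may have more. Where it says the series, first, only, none or still open, it means among the compounds named here.

Working notes on the series. Within the data shown here, the two measured members share one core; compound 1 `COc1ccc2nc(C(F)(F)F)cc(OCC(=O)Nc3cc(C)cc(C)c3)c2c1` and compound 2 `COc1cccc(NC(=O)COc2cc(C)nc3ccc(OC)cc23)c1` carry different groups on that core and on the amide nitrogen. In a toxicity assay on HepG2 cells (Homo sapiens) for inhibition, read by CellTiter-Glo, with a stated time of 48 h (a higher number here means a weaker inhibitor, a lower number a stronger inhibitor), compound 1 returns > 100000 nM, which is a limit of the assay and not a number. Compound 2 likewise gives in this assay only the limit > 100000 nM, again not a number. Among the measured compounds shown here, compound 2 thus stands at the ceiling of what has been measured, as does compound 1, because the limit of > 100000 nM in this assay, at which 2 of the 2 values shown sit, is where every value so far sits. For the measured compounds named here, no two measured compounds differ in a single place, so no step size is on record.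

Compound 3 `COc1ccc2nc(C)cc(OCC(=O)Nc3cccnc3)c2c1` is yet to be measured in this assay. It differs from compound 2 as follows: pyridin-3-yl in place of 3-methoxyphenyl on an amide-type nitrogen. With both measured values resting at the limit, no shift beyond the usual scatter is expected in either direction, and the step of a number no higher from compound 2 to compound 3 (the limit leaves the size open) is expected to be flat. For compound 3 the estimate is 100000 nM, with a range from 50000 nM to 300000 nM, most probably reported once more as a limit.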

Compound 3, half-maximal inhibitory concentration: > 100000 nM
Compound 3: only a limit was reported; the forecaster's own chance of this, stated with the estimate: 85%; the middle value sits exactly at the limit.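

In this assay compound 3 gives > 100000 nM, a limit of the assay and not a number. Among these compounds, compound 2 also rests at a limit, and no step from compound 2 to compound 3 can be read. Every value shown sits at one ceiling: the limit of > 100000 nM in this assay, at which 3 of the 3 values shown sit. The compounds shown leave open whether pyridin-3-yl in place of 3-methoxyphenyl changes inhibition at all.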